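The compounds below may be only part of what the source reports. "The series", "measured", "known", "first", "only" and "open" are said of these compounds alone.

Measured so far:
- compound 1 `CN1CCN(c2nccc3nc(-c4ccc(F)c(F)c4)[nH]c23)CC1`: 130000 nM
- compound 2 `Fc1ccc(-c2nc3c(C4CCNCC4)nccc3[nH]2)cc1F`: 200000 nM
- compound 3 `Fc1ccc(-c2nc3c(N4CCN5CCCC5C4)nccc3[nH]2)cc1F`: 120000 nM

All three numbers come from a physicochemical assay for solubility, read by HPLC, using the shake flask method, in phosphate buffer, with a stated time of 20 h, at pH 6.5; a higher number here means a more soluble compound, a lower number a less soluble compound. In this assay compound 2 gives 200000 nM. It has the highest number of the three, but compound 1 and compound 3 both lie within the usual scatter of it. Scatter here means the differences that repeated measurements of one compound would show anyway, so these three results cannot be ranked with confidence.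

The next compound to be measured is compound 4 `C[C@@H]1CN(c2nccc3[nH]c(-c4ccc(F)c(F)c4)nc23)C[C@H](C)N1`. It differs from compound 2 in one place, on an aromatic carbon, where 3,5-dimethylpiperazin-1-yl stands in place of piperidin-4-yl: 3,5-dimethylpiperazin-1-yl in place of piperidin-4-yl on an aromatic carbon.

Within the data shown here, no two measured compounds differ in one place only, so no single change can be read directly from the data. The expectation rests on the values of compound 1, at 130000 nM, and compound 3, at 120000 nM, whose groups in this place look more like the entering group than piperidin-4-yl does. A small downward step, or none beyond the scatter, is therefore expected. The estimated change is a 1.7-fold lower number from compound 2 to compound 4 (0.22 log units; within the scatter). For compound 4 the estimated value is 120000 nM, with an expected range from 55000 nM to 220000 nM.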

Compound 4, solubility: 190000 nM
The estimate for compound 4 lay 1.6-fold (0.20 log units) below the measured number; the range from low to high includes it.
By their numbers in this assay, from the lowest: compounds 3, 1, 4 and 2 (each within the scatter of the next).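

Among these compounds, with a 1.1-fold lower number from compound 2 to compound 4 (0.02 log units; within the scatter) as the first step in this assay between two compounds that differ in one place only, the comparison at this position no longer has to lean on compounds that differ in more than that. On this aromatic carbon, next to the ring nitrogen, 3,5-dimethylpiperazin-1-yl takes the place of piperidin-4-yl, going from 6 to 8 heavy atoms and bringing 2 defined stereocentres, and the result still cannot be told apart from repeat-measurement scatter, so this change shows no measurable effect on solubility for this pair. No measurement shown here offers a reason for that result.

From the compounds shown here alone, this single step cannot separate the ring nitrogen, the methyl groups and the stereocentres, so it remains open how each contributes, and a plain piperazine with no methyl groups would be the closest test. Going by these compounds, it is also open whether a group of a different kind at this place, such as morpholine, an open-chain amine or a carboxylic acid, would give a step beyond the scatter, and no other step can be read from these compounds.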